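The compounds below may be only part of what the source reports. "The series", "measured", "known", "first", "only" and "open" are said of these compounds alone.

Series so far, in a functional assay (strain AB) with Danio rerio as the target, read by microscopy, with a stated time of 1 h; on this read-out lower numbers stand for an effect already at smaller amounts and higher numbers for an effect only at larger amounts of compound:
- compound 1 `CC(C)(C)OC(=O)CCCC[N+]1(C)CCc2c(sc(NC(=O)Nc3ccc(Cl)cc3)c2C(N)=O)C1`: 140 nM
- compound 2 `CCN1CCc2c(sc(NC(=O)Nc3ccc(Cl)cc3)c2C(N)=O)C1`: 3120 nM

Compound 1 has the lower number of the two in this assay, and the gap to compound 2 lies beyond the scatter. Compound 3 `CC(C)C[N+]1(C)CCc2c(sc(NC(=O)Nc3ccc(Cl)cc3)c2C(N)=O)C1` has not yet been measured. It differs from compound 1 in one place, on a saturated chain carbon bound to an amine nitrogen in a ring: isopropyl in place of 3-(tert-butoxycarbonyl)propyl on a saturated chain carbon bound to an amine nitrogen in a ring. Cut one bond further out, the same difference reads 4-(tert-butoxycarbonyl)butyl to isobutyl. Going by the values given here, no measured pair isolates this change, so the size of the step remains uncertain. Compound 2 also lacks the tert-butoxycarbonyl group and gives 3120 nM, but it differs in more than that one place. A move to a higher number, beyond the scatter, is expected, with an estimated 4.3-fold higher number from compound 1 to compound 3 (0.63 log units; beyond the scatter). The estimate for compound 3 is 600 nM, with an expected range of 130 nM to 2800 nM.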

Compound 3, half-maximal effective concentration: 380 nM
Compound 3: the middle estimate sits 1.6-fold (0.20 log units) above what was measured, and the stated range covers the measured number.
By their numbers in this assay, from the lowest: compound 1; then compound 3; then compound 2.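

In this assay, going by these compounds alone, isopropyl in place of 3-(tert-butoxycarbonyl)propyl on a saturated chain carbon bound to an amine nitrogen in a ring gives a 2.7-fold higher number from compound 1 to compound 3 (0.43 log units; beyond the scatter), the first step that isolates this position. The step is beyond the scatter but modest: with the tert-butoxycarbonyl group and its hydrogen-bond acceptors gone, compound 3 still gives 380 nM, so this ester-bearing chain is not needed for a measurable effect at this position. No measured property accounts for the size of this step.

The compounds shown leave open whether the step follows the tert-butoxycarbonyl group itself or the length of the chain. A plain unbranched butyl chain, or a chain ending in a carboxylic acid or an amine, would separate these two readings.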